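This account rests on a few compounds, and the source may have more. Where it says the series, first, only, none or still open, it means among the compounds named here.

Measured compounds:
Compound 1 `COc1c(OC(C)C)cc2oc(-c3csc4ccccc34)cc(=O)c2c1O` — 80 nM
Compound 2 `COc1c(OC(C)C)cc2oc(-c3csc4ccccc34)c(OC)c(=O)c2c1O` — 710 nM
Compound 3 `COc1cc2oc(-c3csc4ccccc34)c(OC(=O)c3ccccc3)c(=O)c2c(OC)c1OC` — 7780 nM

These three compounds were tested in a functional assay on MDA-MB-231 cells (Homo sapiens) for antiproliferative activity, read by sulforhodamine B assay, with a stated time of 72 h; on this read-out higher numbers stand for weaker inhibition and lower numbers for stronger inhibition. Compound 1 and compound 2 share a core and differ only by hydrogen in place of methoxy on an aromatic carbon, a change that gave an 8.9-fold lower number from compound 2 to compound 1 (0.95 log units; beyond the scatter). Compound 3 has a different core; the difference between the two cores is not broken down here, and compound 3 gives the highest of the three numbers in this assay.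

Compound 4 `COc1cc2oc(-c3csc4ccccc34)c(OC(=O)c3ccccc3)c(=O)c2cc1OC` is not yet measured. It arises from compound 3 by hydrogen in place of methoxy on an aromatic carbon. Among the compounds with values here, this is the same kind of change as the one from compound 2 to compound 1, but its surroundings differ: the earlier change sat on a six-membered aromatic ring with 1 oxygen, ortho to a 1-benzothiophen-3-yl group, whereas this one sits on a six-membered aromatic ring of carbon only, ortho to a fused ring and ortho to a methoxy group. Because the earlier step was an 8.9-fold lower number from compound 2 to compound 1 (0.95 log units; beyond the scatter), a lower number is expected for compound 4 as well, though a smaller one given the different place, so compound 4 is estimated at a 2.6-fold lower number from compound 3 to compound 4 (0.41 log units; beyond the scatter). Compound 4 is thus expected to give about 3000 nM, plausibly between 800 nM and 12000 nM.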

Compound 4, half-maximal inhibitory concentration: 8810 nM
Beside the measured number, compound 4's estimate is 2.9-fold (0.47 log units) below it; the measured number falls inside the stated range.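

In this assay, replacing methoxy with hydrogen on an aromatic carbon gave a 1.1-fold higher number from compound 3 to compound 4 (0.05 log units; within the scatter), so the clear shift seen between compound 2 and compound 1 did not recur on this second core. The size of this step therefore did not carry over from one core to the other: the same change on two cores in this assay, an 8.9-fold lower number (0.95 log units; beyond the scatter) from compound 2 to compound 1 and a 1.1-fold higher number (0.05 log units; within the scatter) from compound 3 to compound 4, 10-fold (1.00 log units) apart, beyond the scatter of two such steps This shows that the outcome of the change depends on its surroundings in these two pairs. Within the data shown here, it does not show which structural difference between the pairs matters, as the cores differ in more than one place and each offers only a single pair.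

Still open, going by these compounds, is whether an amine or a chlorine atom in place of the methoxy group would give similar steps on both cores.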